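A few compounds are considered here, and "the series" means these few. Any claim that something is new, unique, unknown or untested is made for them only; others in the source may bear on it.

Measured so far:
- Compound 1 `O=C(O)CCCCC(CCSC(=O)c1ccccc1)SC(=O)c1ccccc1`: 0.68%
- Compound 2 `O=C(CCCCC(CCSC(=O)c1ccccc1)SC(=O)c1ccccc1)Nc1cccc(Cl)c1`: 12.7%

Within the data shown here, in a functional assay on KB cells (Homo sapiens) for inhibition, read by MTT assay, with a stated time of 24 h, tested at 1 ug/mL (on this read-out higher numbers stand for more inhibition of growth at the one concentration tested and lower numbers for less inhibition of growth), compound 2 gives 12.7%, the higher of the two numbers so far, while compound 1 gives 0.68%. Among the measured compounds shown here, only one measured step exists, a number 12 percentage points higher from compound 1 to compound 2 (beyond the scatter), and it comes with (3-chlorophenyl)amino in place of hydroxy on a carbonyl carbon. The next compound to be tested is compound 3 `O=C(CCCCC(CCSC(=O)c1ccccc1)SC(=O)c1ccccc1)Nc1ccc(Cl)cc1`. It has the same atoms as compound 2, joined differently: 4-chlorophenyl in place of 3-chlorophenyl on an amide-type nitrogen. In words, 4-chlorophenyl stands in place of 3-chlorophenyl on an amide-type nitrogen.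

For the measured compounds named here, no measurement yet compares these two groups, so the single measured step bears on the change only loosely. That step, a number 12 percentage points higher from compound 1 to compound 2 (beyond the scatter), replaced hydroxy altogether and was itself modest, which gives little reason to expect a larger change from a swap between two chlorophenyl groups. In this assay, the expected outcome is therefore no clear shift in either direction, with the estimated step being a number 0.3 percentage points higher from compound 2 to compound 3 (within the scatter). Compound 3 is estimated at 13%, with an expected range from 3% to 28%.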

Compound 3, percent growth inhibition at one concentration: 11.7%
The estimate for compound 3 lay 1.3 percentage points above the measured number; the range from low to high includes it.
By their numbers in this assay, from the lowest: compound 1; then compounds 3 and 2 (each within the scatter of the next).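

In this assay, putting 4-chlorophenyl in place of 3-chlorophenyl on the amide-type nitrogen gives a number 1 percentage points lower from compound 2 to compound 3 (within the scatter) and so leaves the number effectively unchanged; at this one concentration, the two chlorophenyl groups cannot be told apart. The earlier compounds shown here offered only one replacement of hydroxy on the carbonyl carbon, whereas (4-chlorophenyl)amino in that place now gives a number 11 percentage points higher from compound 1 to compound 3 (beyond the scatter) as a second example, so the modest gain seen with (3-chlorophenyl)amino is not confined to that one group. Nothing measured here gives a reason for either result.

On these data alone, whether the chlorine matters at all remains open, since plain phenyl on the same nitrogen would be needed to separate the contribution of the chlorine from that of the aromatic ring, and 2-chlorophenyl or 4-methoxyphenyl would show how far this tolerance on the ring extends. The compounds shown also leave open whether a simple amide without a ring, such as one carrying a butyl group, would give a similar gain over compound 1 in this test.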